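The compounds below may be only part of what the source reports. "The series", "measured", "known", "first", "only" and "open" are said of these compounds alone.

Measured compounds:
compound 1, `CCOc1ccc(Br)cc1-c1cc(Nc2ccc(/C(C)=N\O)cc2)nc(N)n1`, 84 nM
compound 2, `Cc1ccc(Br)cc1-c1cc(Nc2ccc(Cl)cc2)nc(N)n1`, 31 nM

Both compounds were tested in an assay on Sf9 cells for inhibition of 1-acyl-sn-glycerol-3-phosphate acyltransferase beta (Homo sapiens); on this read-out lower numbers stand for stronger inhibition and higher numbers for weaker inhibition. Compound 1 gives 84 nM, while compound 2 gives 31 nM. Compound 2 thus has the lowest number of the two; its nearest neighbour is compound 1, whose number is higher by a gap beyond the usual scatter, so compound 2 is the stronger inhibitor of this pair. Going by the values given here, the two compounds differ in more than one place, so no single step between them has been worked out, and their values show only that difference in strength.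

Compound 3, `CCOc1ccc(Br)cc1-c1cc(Nc2ccc(Cl)cc2)nc(N)n1`, is built from compound 2 by one change: ethoxy in place of methyl on an aromatic carbon. No measured step of this kind exists among the compounds shown, so its effect can only be anticipated. The expectation is a small step from compound 2, most likely within the scatter or at most a modest weakening, of about a 1.5-fold higher number from compound 2 to compound 3 (0.16 log units; within the scatter). Compound 3 is therefore estimated to give 45 nM in this assay, with a likely range from 15 nM to 150 nM.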

Compound 3, half-maximal inhibitory concentration: 16 nM
The estimate for compound 3 lay 2.8-fold (0.45 log units) above the measured number, within the range that was stated.
By their numbers in this assay, from the lowest: compounds 3 and 2 (each within the scatter of the next); then compound 1.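

At this aromatic carbon, ortho to a large group and para to a bromo group, ethoxy in place of methyl gives a 1.9-fold lower number from compound 2 to compound 3 (0.29 log units; within the scatter) in this assay, so the two groups cannot be told apart here even though ethoxy carries 3 heavy atoms and methyl only 1. Compound 3 also links the two earlier compounds, which differed in more than one place: with ethoxy held constant, one chlorine atom in place of a group of 4 heavy atoms gives a 5.3-fold lower number from compound 1 to compound 3 (0.72 log units; beyond the scatter), a real though modest gain in strength that can be traced to that single change. Nothing here measures why either change has the effect it does.

Still open, as far as these compounds go, is how far this position can be pushed, since a longer chain such as butoxy, or a small group such as an amine, could show whether inhibition holds or falls away. It is also unknown whether the chlorine step keeps its size when methyl rather than ethoxy sits on the aromatic carbon.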